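Cyclopentyl for cyclohexyl on the amide nitrogen

The source may report more compounds than this note shows. Statements on the series, on what has been measured and on what is new or still open speak of the compounds shown alone.

Measured so far:
compound 1, `N=c1oc2ccc(Br)cc2cc1C(=O)NC1CCCCC1`: 10%
compound 2, `COc1cccc2cc(C(=O)NC3CCCCC3)c(=N)oc12`: > 70%

Two compounds have been run in an assay on HEK293 cells for displacement of a labelled ligand from adenosine receptor A2b (Homo sapiens), read by scintillation counting, with a stated time of 30 min, tested at 10 uM; a lower number here means less inhibition, a higher number more inhibition at the concentration tested (going by the name of the read-out). For the measured compounds named here, compound 1 gives 10%, the only plain number in the set. Compound 2 is reported as a limit of the assay, > 70%, not as a number (the limit of > 70% in this assay, at which 1 of the 2 values shown sits). Compound 1 and compound 2 differ in more than one place, so no single step can be read between them.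

Compound 3, `N=c1oc2ccc(Br)cc2cc1C(=O)NC1CCCC1`, has not yet been measured in this assay. It differs from compound 1 by cyclopentyl in place of cyclohexyl on an amide-type nitrogen. Going by the values given here, no measured step of this kind exists, so its size is open. The swap of one small carbocycle for another at the same position is expected to move the read-out in this assay by no more than the usual scatter, in no set direction. Compound 3 is therefore expected to give 12% in this assay, between 0% and 30%. The expected step of a number 2 percentage points higher from compound 1 to compound 3 (within the scatter) is judged to lie within the scatter.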

Compound 3, a percentage reported as inhibition, at one concentration (the size of the read-out at that concentration, not a potency): 28%
Compound 3: the middle estimate sits 16 percentage points below what was measured; low and high end bracket the measured number.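

In this assay, for the compounds shown here, the change from cyclohexyl to cyclopentyl on an amide-type nitrogen gives the first step that can be read at a single place: a number 18 percentage points higher from compound 1 to compound 3 (beyond the scatter). This shows that the read-out at this position responds to the choice between these two carbocycles, even though neither group carries a hydrogen-bond donor or acceptor. Nothing measured in the series accounts for this step.

Going by these compounds, one pair sets no trend, so it remains open how a smaller cyclobutyl ring, a longer chain such as n-hexyl, or a piperidine ring carrying a basic amine would read on this nitrogen. Steps to compound 2 cannot be read, as it differs from compound 1 and compound 3 in more than one place.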